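The source may report more compounds than this note shows. Statements on the series, on what has been measured and on what is new or still open speak of the compounds shown alone.

Three compounds of this series have been measured in an assay on LM cells for displacement of a labelled ligand from Neuropeptide Y receptor type 5 (Homo sapiens) (on this read-out lower numbers stand for stronger inhibition and higher numbers for weaker inhibition), so far:

Compound 1, `N#Cc1cccc(C2=NC(c3ccc(F)cc3)(c3ccc(F)cc3)CN2)c1`: 2.7 nM
Compound 2, `O=Cc1cccc(C2=NC(c3ccc(F)cc3)(c3ccc(F)cc3)CN2)c1`: 8.7 nM
Compound 3, `Fc1ccc(C2(c3ccc(F)cc3)CNC(c3ccccn3)=N2)cc1`: 160 nM

Compound 2 holds the second highest of the three numbers. Its nearest neighbour is compound 1, separated by a modest step, a 3.2-fold higher number from compound 1 to compound 2 (0.51 log units; beyond the scatter), which corresponds to formyl in place of cyano on an aromatic carbon. Its furthest neighbour is compound 3, reached by a large step, an 18-fold higher number from compound 2 to compound 3 (1.26 log units; beyond the scatter).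

Compound 4, `Fc1ccc(C2(c3ccc(F)cc3)CNC(c3cncnc3)=N2)cc1`, has not been measured. It differs from compound 2 in one place: pyrimidin-5-yl in place of 3-formylphenyl on a carbon with a double bond to nitrogen.

Going by the values given here, the step that bears most directly on this change is the one from compound 2 to compound 3, which also removes 3-formylphenyl from the carbon with a double bond to nitrogen and puts a six-membered aromatic ring with nitrogen in its place; that step was large, an 18-fold higher number from compound 2 to compound 3 (1.26 log units; beyond the scatter). The parallel step from compound 1, a 59-fold higher number from compound 1 to compound 3 (1.77 log units; beyond the scatter), points the same way. Only one such replacement has been measured, so the size is uncertain, but a large step towards a higher number is expected, an 11-fold higher number from compound 2 to compound 4 (1.06 log units; beyond the scatter).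

For compound 4 the estimate in this assay is 100 nM, with a range from 30 nM to 400 nM.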

Compound 4, half-maximal inhibitory concentration: 47 nM
Compound 4: middle estimate off by 2.1-fold (0.33 log units), on the high side; measured number inside the range.
By their numbers in this assay, from the lowest: compound 1; then compound 2; then compound 4; then compound 3.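

In this assay the carbon with a double bond to nitrogen does not treat all nitrogen-containing six-membered rings alike: pyrimidin-5-yl in place of pyridin-2-yl gives a 3.4-fold lower number from compound 3 to compound 4 (0.53 log units; beyond the scatter) and so recovers part of what the first such replacement lost. Against the substituted phenyl groups the loss remains, with a 5.4-fold higher number from compound 2 to compound 4 (0.73 log units; beyond the scatter) and a 17-fold higher number from compound 1 to compound 4 (1.24 log units; beyond the scatter) as the two steps, so among these four compounds both 3-formylphenyl and 3-cyanophenyl keep lower numbers than either nitrogen-containing ring, with no compound going against this. Nothing available on these compounds accounts for the order of the two rings.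

A pyridin-3-yl group on this carbon would help separate the placement of the ring nitrogen from the number of ring nitrogens, a question these two rings alone leave open. From the compounds shown here alone, it also remains open how an amine or a carboxylic acid in place of the formyl of 3-formylphenyl would read on this receptor, and whether such a group on a pyrimidin-5-yl ring would close the remaining gap.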